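This account rests on a few compounds, and the source may have more. Where it says the series, first, only, none or still open, it means among the compounds named here.

Three compounds sharing one fused core were tested in an assay on HEK293 cells for negative allosteric modulation of metabotropic glutamate receptor 5 (Homo sapiens), read by FLIPR, with a stated time of 1 h; on this read-out lower numbers stand for stronger inhibition and higher numbers for weaker inhibition. Compound 1 `O=C1NCCc2nc(C#Cc3cccc(F)c3)sc21` reaches only a limit there, > 10000 nM, which is not a number. Compound 2 `Fc1cccc(C#Cc2nc3c(s2)CN(C2CCC2)CC3)c1` gives 200 nM in this assay. Compound 3 `CC(=O)N1CCc2nc(C#Cc3ccccc3)sc2C1`, whose ring nitrogen carries an acetyl, gives 90 nM in this assay. Among the two numbers recorded, compound 3 has the lowest, and compound 2 stands at a higher number, a gap beyond the usual scatter. Compound 1 is set apart by the limit of > 10000 nM in this assay, at which 1 of the 3 values shown sits, so it cannot be ranked against the others.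

Compound 4 `CC(C)S(=O)(=O)N1CCc2nc(C#Cc3ccccc3)sc2C1` has not yet been measured. It differs from compound 3 in one place: isopropylsulfonyl in place of acetyl on an amine nitrogen in a ring. Among the measured compounds shown here, no pair of measured compounds isolates this kind of exchange, so the expectation rests on compound 3 alone. Swapping one small capping group on the ring nitrogen for another is expected to move the number only modestly, and the direction is uncertain. The expected step is a 1.3-fold lower number from compound 3 to compound 4 (0.11 log units; within the scatter), close to what repeated measurements would show. Compound 4 is therefore expected to give about 70 nM in this assay, most likely between 20 nM and 250 nM.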

Compound 4, half-maximal inhibitory concentration: 11 nM
Compound 4: the middle estimate sits 6.4-fold (0.80 log units) above what was measured, outside the stated range (below it).
By their numbers in this assay, from the lowest: compound 4; then compound 3; then compound 2. At a limit, above all of these: compound 1.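

In this assay, the group on this amine nitrogen turns out to matter a great deal: exchanging acetyl for isopropylsulfonyl gives an 8.2-fold lower number from compound 3 to compound 4 (0.91 log units; beyond the scatter). The earlier compounds shown here included no pair differing in one place, so they could not show that a change at this position alone can shift the number this far. The incoming isopropylsulfonyl has 6 heavy atoms and 2 hydrogen-bond acceptors against 3 and 1 for acetyl, but nothing measured here shows which of these differences, if any, accounts for the step.

Going by these compounds, it remains open whether the sulfonyl or the isopropyl part carries the step, and a methylsulfonyl or an isobutyryl on the same nitrogen would help separate the two. Also open, on these data alone, is whether the same exchange gives a similar step in compounds with a fluorine on the phenyl ring, or whether its size depends on the unsubstituted phenyl shared by compound 3 and compound 4.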